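The source may hold more compounds than are shown below. What is called first, only, known or untested is meant among the compounds shown, and "the series" means these compounds.

Compound 1 `COc1ccc(C(=O)/C=C\Nc2ccc(-c3nc4cc(OC)c(OC)c(OC)c4s3)cc2)cc1O` and compound 2 `COc1ccc2nc(-c3ccc(N/C=C\C(=O)c4ccc(OC)c(O)c4)cc3)sc2c1` differ in their cores; the difference between the two cores is not broken down here. In a functional assay on MDA-MB-231 cells (Homo sapiens) for antiproliferative activity, read by sulforhodamine B assay, with a stated time of 48 h (a higher number here means a weaker inhibitor, a lower number a stronger inhibitor), compound 1 gives 18100 nM and compound 2 gives 18900 nM. Compound 3 `COc1ccc2nc(-c3ccc(N/C=C\C(=O)c4ccc(OC)c([N+](=O)[O-])c4)cc3)sc2c1` carries, relative to compound 2, the change (nitro in place of hydroxy on an aromatic carbon); in this assay compound 3 gives 17600 nM, and the step is a 1.1-fold lower number from compound 2 to compound 3 (0.03 log units; within the scatter). Compound 4 `COc1ccc(C(=O)/C=C\Nc2ccc(-c3nc4cc(OC)c(OC)c(OC)c4s3)cc2)cc1[N+](=O)[O-]` is not yet measured and carries the same change relative to compound 1, (nitro in place of hydroxy on an aromatic carbon), at a place described in identical words in both pairs. For compound 4 the expected step in this assay is a 1.1-fold lower number from compound 1 to compound 4 (0.03 log units; within the scatter), because a 1.1-fold lower number from compound 2 to compound 3 (0.03 log units; within the scatter) stayed within the scatter. Compound 4 is therefore estimated at 17000 nM, with a range from 9000 nM to 34000 nM.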

Compound 4, half-maximal inhibitory concentration: 17100 nM
The estimate for compound 4 lay 1.0-fold (0.00 log units) below the measured number, within the range that was stated.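

In this assay, nitro in place of hydroxy gives a 1.1-fold lower number from compound 1 to compound 4 (0.02 log units; within the scatter), and the change reads alike on the two cores: the same change on two cores in this assay, a 1.1-fold lower number (0.03 log units; within the scatter) from compound 2 to compound 3 and a 1.1-fold lower number (0.02 log units; within the scatter) from compound 1 to compound 4, 1.0-fold (0.01 log units) apart, within the scatter of two such steps. The swap therefore carries from the core of compound 2 to the core of compound 1 with no step beyond the scatter in either pair. This shows agreement only for these two pairs, at this one place and in this one assay; it does not show that the two groups are interchangeable on other cores, or that a change with a larger step would carry in the same way.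

Open, on these data alone, is whether an amine or a carboxylic acid at this place on the ring would also leave the number within the scatter. Also open, as far as these compounds go, is whether the nitro for hydroxy change stays as flat when the methoxy group is replaced by a longer chain.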